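Reversing the aminomethyl-pyrrolidine linkage on the biphenyl series

The source may report more compounds than this note shows. Statements on the series, on what has been measured and on what is new or still open speak of the compounds shown alone.

Three compounds have numbers in an assay on isolated protein for inhibition of DNA topoisomerase 1 (Homo sapiens), with a stated time of 15 min; a lower number here means a stronger inhibitor, a higher number a weaker inhibitor. Compound 1 `O=C(O)c1cn(Cc2ccc(-n3cccn3)cc2)c2cc(NC[C@H]3CCNC3)c(F)cc2c1=O` gives 187000 nM, compound 2 `CNC[C@@H]1CCN(c2cc3c(cc2F)c(=O)c(C(=O)O)cn3Cc2ccc(-c3ccccc3)cc2)C1` gives 168000 nM, and compound 3 `NC[C@@H]1CCN(c2cc3c(cc2F)c(=O)c(C(=O)O)cn3Cc2ccc(-c3ccccc3)cc2)C1` gives 15600 nM. Compound 3 stands at the lowest number of the three, its nearest neighbour being compound 2 and the step of an 11-fold lower number from compound 2 to compound 3 (1.03 log units; beyond the scatter) coming from hydrogen in place of methyl on an amine nitrogen.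

Compound 4 `O=C(O)c1cn(Cc2ccc(-c3ccccc3)cc2)c2cc(NC[C@H]3CCNC3)c(F)cc2c1=O` keeps the biphenyl side of compound 3 and differs only in the change (((pyrrolidin-3-yl)methyl)amino in place of 3-(aminomethyl)pyrrolidin-1-yl on an aromatic carbon). Among the compounds with values here, no measured pair isolates this change, so the step from compound 2 to compound 3 gives no direct guide. Compound 1 carries the same entering group on a different benzyl substituent and shows a much higher number than compound 3, though it differs in two places and supplies only a loose pointer. A moderate rise in the number, a 3.8-fold higher number from compound 3 to compound 4 (0.59 log units; beyond the scatter), is therefore expected for compound 4. The estimate for compound 4 in this assay is 60000 nM, with a range from 15000 nM to 250000 nM.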

Compound 4, half-maximal inhibitory concentration: 100000 nM
Estimate against measurement, compound 4: 1.7-fold (0.22 log units) below, and the stated range covers the measured number.
By their numbers in this assay, from the lowest: compound 3; then compounds 4, 2 and 1 (each within the scatter of the next).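

In this assay, with the same atoms joined differently, ((pyrrolidin-3-yl)methyl)amino in place of 3-(aminomethyl)pyrrolidin-1-yl on the aromatic carbon ortho to the fluoro group does not preserve the number of compound 3 (a 6.4-fold higher number from compound 3 to compound 4 (0.81 log units; beyond the scatter)). This linkage change alone therefore gives a modest loss, and the result lies within the scatter of the methylated amine (a 1.7-fold lower number from compound 2 to compound 4 (0.23 log units; within the scatter)). With ((pyrrolidin-3-yl)methyl)amino in place, phenyl in place of 1H-pyrazol-1-yl also gives no readable separation (a 1.9-fold lower number from compound 1 to compound 4 (0.27 log units; within the scatter)).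

As far as these compounds go, whether a piperidine or azetidine ring carrying the same aminomethyl group would hold the number of compound 3 remains open. No supporting data explain the effect of the linkage change.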